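This account rests on a few compounds, and the source may have more. Where it says the series, first, only, none or still open, it means among the compounds named here.

Compound 1 `C#CCSc1nc(Nc2ccc(C)cc2)c2ccncc2n1` and compound 2 `C#CCSc1nc(Nc2cccc(Cl)c2)c2ccncc2n1` share one core and differ only in the group carried on the nitrogen on the aromatic ring. In a functional assay on PC-3 cells (Homo sapiens) for inhibition, read by MTT assay, with a stated time of 72 h (on this read-out higher numbers stand for weaker inhibition and lower numbers for stronger inhibition), compound 1 gives 15700 nM. In this assay, going by the values given here, compound 2 gives 56500 nM, the highest of the two numbers measured so far; the one measured step, a 3.6-fold higher number from compound 1 to compound 2 (0.56 log units; beyond the scatter), is modest and lies beyond the scatter. Compound 3 `C#CCSc1nc(Nc2ccc(O)cc2)c2ccncc2n1` has not yet been measured. The change from compound 2 to compound 3 is 4-hydroxyphenyl in place of 3-chlorophenyl on a nitrogen on an aromatic ring. Among the compounds with values here, only that single step bears on this change: it shows that the group on this nitrogen moves the number, and that 3-chlorophenyl gave the higher one, while 4-methylphenyl gave the lower. Within the data shown here, no measured compound carries 4-hydroxyphenyl on this nitrogen, so the direction rests on a single comparison. Compound 3 is expected to move back toward a lower number, with the step of a 2.3-fold lower number from compound 2 to compound 3 (0.35 log units; beyond the scatter) estimated to be modest. In this assay compound 3 is estimated at 25000 nM, within a range from 8000 nM to 80000 nM.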

Compound 3, half-maximal inhibitory concentration: > 80000 nM
Compound 3 gave a limit, no number (the forecaster's own chance of this, stated with the estimate: 10%); middle value at least 3.2-fold (0.50 log units) from the limit.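

In this assay compound 3 stands as a limit of the assay and not as a number: the limit of > 80000 nM in this assay, at which 1 of the 3 values shown sits. Hydroxy in place of methyl on an aromatic carbon gives an at least 5.0-fold higher number from compound 1 to compound 3 (0.70 log units; beyond the scatter), so the group on this nitrogen can move the read-out toward weaker inhibition by more than the earlier pair alone had shown, and a small change on the aromatic ring is enough to do it. Against 3-chlorophenyl, the change to 4-hydroxyphenyl gives an at least 1.4-fold higher number from compound 2 to compound 3 (0.15 log units; that floor lies within the scatter); that floor lies within the scatter, so this step fixes no order between the two groups, and only the step from 4-methylphenyl can be read as a real difference.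

On these data alone, how far compound 3 lies beyond its limit stays unknown, which leaves the full size of both steps open. The compounds shown also leave open what 4-methoxyphenyl or 4-aminophenyl on this nitrogen would give, and so whether the loss seen with 4-hydroxyphenyl belongs to the hydroxy group alone or extends to other groups bearing oxygen or nitrogen on the ring.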